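Cytotoxicity notes: from compound 2 to compound 4

This account rests on a few compounds, and the source may have more. Where it says the series, first, only, none or still open, it means among the compounds named here.

- Compound 1 `Cc1cc(C)cc(S(=O)(=O)n2c(SCC(=O)Nc3ccccc3Cl)nc3ccccc32)c1`: 107000 nM
- Compound 2 `Cc1cc(C)cc(S(=O)(=O)n2c(SCC(=O)Nc3ccccc3[N+](=O)[O-])nc3ccccc32)c1`: >= 26000 nM, a limit
- Compound 3 `Cc1cc(C)cc(S(=O)(=O)n2c(SCC(=O)Nc3ccccc3[N+](=O)[O-])nc3ccc(Cl)cc32)c1`: > 235000 nM, a limit

In an ADME assay on MT4 cells (Homo sapiens) for cytotoxicity (a lower number here means that less compound is tolerated, a higher number that more compound is tolerated), compound 2 is known only as a limit, >= 26000 nM. Compound 4 `Cc1cc(C)cc(S(=O)(=O)n2c(SCC(=O)Nc3ccc(C)cc3Cl)nc3ccccc32)c1` differs from it by 2-chloro-4-methylphenyl in place of 2-nitrophenyl on an amide-type nitrogen. The two measured steps that bear on this change give no size: a step that the limit leaves unreadable from compound 1 to compound 2, and a step that the two limits leave unreadable from compound 2 to compound 3. Within the data shown here, the only plain number in this assay is that of compound 1, 107000 nM, so the expectation is anchored there. The estimated change is a step that the limit leaves unreadable from compound 2 to compound 4, expected toward more compound tolerated. Compound 4 is expected at 90000 nM, with an estimated range of 30000 nM to 250000 nM.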

Compound 4, half-maximal cytotoxic concentration: 5400 nM
Compound 4: middle estimate off by 17-fold (1.22 log units), on the high side; the measured number lies below the stated range.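

In this assay, among these compounds, a single added methyl gives a 20-fold lower number from compound 1 to compound 4 (1.30 log units; beyond the scatter) on the group carried by the amide-type nitrogen, the first step of readable size at this place. The change of 2-nitrophenyl to 2-chloro-4-methylphenyl gives an at least 4.8-fold lower number from compound 2 to compound 4 (0.68 log units; beyond the scatter) and so also points to a lower number. No measured property shown accounts for either step.

Going by these compounds, whether an ethyl, a methoxy or a carboxylic acid in place of that methyl would lower the number in the same way stays open. So does whether the methyl has a similar effect on the 2-nitrophenyl group.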